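From Cycloheptyl to 4-Fluorophenyl at the Amine-Bound Carbon

The source may hold more compounds than are shown below. What is called first, only, known or untested is meant among the compounds shown, and "the series" means these compounds.

Compound 2 `COc1cc(N)c(Cl)cc1NC(=O)C1CCN(CC2CCCCCC2)CC1` has been tested in a functional assay on the whole organism for antagonist activity, with Mus musculus as the target; on this read-out lower numbers stand for an effect already at smaller amounts and higher numbers for an effect only at larger amounts of compound. In this assay compound 2 gives only a limit, > 10 mg/kg. Its closest relative, compound 1 `CCCCCCCN1CCC(C(=O)Nc2cc(Cl)c(N)cc2OC)CC1`, likewise gives only a limit in this assay, > 10 mg/kg. Going by the values given here, the single measured step, a step that the two limits leave unreadable from compound 1 to compound 2, cannot be read because of the limit of > 10 mg/kg in this assay, at which 2 of the 2 values shown sit. Compound 3 `COc1cc(N)c(Cl)cc1NC(=O)C1CCN(Cc2ccc(F)cc2)CC1` differs from compound 2 by 4-fluorophenyl in place of cycloheptyl on a saturated chain carbon bound to an amine nitrogen in a ring. Among the compounds with values here, no measured step bears on this change, so neither direction nor size can be drawn from the data. Compound 3 is expected to remain weak, estimated at 15 mg/kg within 4 mg/kg to 60 mg/kg. This amounts to an expected step that the limit leaves unreadable from compound 2 to compound 3.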

Compound 3, dose for half-maximal effect: 0.6 mg/kg
Estimate against measurement, compound 3: 25-fold (1.40 log units) above; the measured number lies below the stated range.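

In this assay, the place on a saturated chain carbon bound to an amine nitrogen in a ring now shows a readable change: 4-fluorophenyl in place of cycloheptyl gives an at least 16-fold lower number from compound 2 to compound 3 (1.22 log units; beyond the scatter), and 4-fluorophenyl in place of hexyl gives an at least 16-fold lower number from compound 1 to compound 3 (1.22 log units; beyond the scatter). Of the three compounds, only compound 3, with its aromatic ring at this place, gives a measured number. The full size of both steps stays unknown, as each starts from a limit: the limit of > 10 mg/kg in this assay, at which 2 of the 3 values shown sit.

Going by these compounds, whether the aromatic ring alone or the fluorine on it goes with this drop stays open. A plain phenyl group at this place would speak to that.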